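This account rests on a few compounds, and the source may have more. Where it says the series, first, only, none or still open, it means among the compounds named here.

Measured compounds in an assay on isolated protein for inhibition of Caspase-8 (Homo sapiens); on this read-out lower numbers stand for stronger inhibition and higher numbers for weaker inhibition:
compound 1 `CN1C[C@@H]2CCCC[C@H](NC(=O)c3ccccc3)C(=O)N2[C@H](C(=O)N[C@H]2CC(=O)OC2O)C1`: 247 nM
compound 2 `O=C1C[C@H](NC(=O)[C@@H]2COC[C@@H]3CCCC[C@H](NC(=O)c4nccc5ccccc45)C(=O)N32)C(O)O1`: 264 nM
compound 3 `O=C1C[C@H](NC(=O)[C@@H]2COC[C@@H]3C/C=C\C[C@H](NC(=O)c4ccccc4C(F)(F)F)C(=O)N32)C(O)O1`: 670 nM

Compound 3 stands at the highest number of the three in this assay. The nearest of the others is compound 2, and the gap to it lies beyond the usual scatter; compound 1 lies a little further off again, also beyond the scatter. Among the measured compounds shown here, no pair among the three differs in only one place, so no single-change step can be read from the measured set, and the core of compound 3 with its unsaturated ring appears only once.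

Compound 4 `O=C1C[C@H](NC(=O)[C@@H]2COC[C@@H]3C/C=C\C[C@H](NC(=O)c4ccc5ccccc5c4)C(=O)N32)C(O)O1` keeps the core of compound 3 and changes only the acyl group: naphthalen-2-yl in place of 2-(trifluoromethyl)phenyl on a carbonyl carbon. Compound 2 shows that a bicyclic aroyl group on a related core can give 264 nM, but compound 2 also carries a different core, so that reading is indirect. The expectation for this assay is a modest step towards a lower number, a 1.7-fold lower number from compound 3 to compound 4 (0.22 log units; within the scatter), not far outside the scatter. Compound 4 is estimated at 400 nM, with a range of 150 nM to 1100 nM.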

Compound 4, half-maximal inhibitory concentration: 2590 nM
The estimate for compound 4 lay 6.5-fold (0.81 log units) below the measured number, and the stated range ends below it.
By their numbers in this assay, from the lowest: compounds 1 and 2 (each within the scatter of the next); then compound 3; then compound 4.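

In this assay, among the compounds shown here, naphthalen-2-yl in place of 2-(trifluoromethyl)phenyl on a carbonyl carbon gives a 3.9-fold higher number from compound 3 to compound 4 (0.59 log units; beyond the scatter), the first single-change reading. With the core held constant, this shows that the read-out responds to the aryl part of this acyl group, even though both groups have the same heavy-atom count and neither has a hydrogen-bond donor or acceptor. No measurement shown bears on the origin of this step.

Open, on these data alone, is how unsubstituted phenyl, 2-chlorophenyl or naphthalen-1-yl on the same carbonyl carbon of the core of compound 3 would compare with compound 3 and compound 4, which would help separate the loss of the trifluoromethyl group from the entry of the second aromatic ring. Whether the step carries over to the cores of compound 1 and compound 2 also remains open, since the compounds shown include no pair with the same acyl group on two different cores.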